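The source may hold more compounds than are shown below. What is called first, only, known or untested is meant among the compounds shown, and "the series" means these compounds.

Measured compounds:
compound 1, `O=C(Nc1cccc(F)c1)c1cc(C(F)(F)F)ccc1OCc1ccc(F)cc1`: < 1000 nM
compound 2, `O=C(Nc1ccnnc1)c1cc(N2CCC(F)CC2)ccc1OCc1ccccc1`: 20000 nM

Both were examined in a physicochemical assay for solubility, measured as kinetic solubility; on this read-out lower numbers stand for lower solubility and higher numbers for higher solubility. For compound 1 the result of < 1000 nM is a limit of the assay rather than a number. For the measured compounds named here, compound 2, which in this assay gives 20000 nM, thus carries the only real number in this set; the other entry is the limit of < 1000 nM in this assay, at which 1 of the 2 values shown sits. Going by the values given here, no pair of measured compounds differs in a single place, so no measured step can be drawn on for the next change.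

Compound 3, `N#CC1CCN(c2ccc(OCc3ccccc3)c(C(=O)Nc3ccnnc3)c2)CC1`, has not yet been run in this assay. It differs from compound 2 by cyano in place of fluoro on a saturated ring carbon. Cut one bond further out, the change reads as 4-fluoropiperidin-1-yl to 4-cyanopiperidin-1-yl. Nothing measured here speaks to such an exchange. The step of a 1.3-fold higher number from compound 2 to compound 3 (0.10 log units; within the scatter) is expected to be small, a slight rise at most, and within the usual scatter of the assay. Compound 3 is therefore estimated to give about 25000 nM in this assay, with a likely range from 8000 nM to 70000 nM.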

Compound 3, solubility: < 1000 nM
Compound 3 gave a limit, no number; the forecaster's own chance of this, stated with the estimate: 10%; middle value at least 25-fold (1.39 log units) away from the limit.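

Moving from 4-fluoropiperidin-1-yl to 4-cyanopiperidin-1-yl changes the result in this assay far more than the earlier compounds could indicate, giving an at least 20-fold lower number from compound 2 to compound 3 (1.30 log units; beyond the scatter). This shows that a saturated ring carbon three ring bonds from the ring nitrogen is not a neutral place for this exchange, since a change at this one place, with the rest of the molecule the same, separates the two compounds by more than the scatter. For compound 3 the result of < 1000 nM is a limit of the assay, and this limit now accounts for most of the set: the limit of < 1000 nM in this assay, at which 2 of the 3 values shown sit.

The compounds shown leave open whether this large step is particular to the nitrile or would also follow from other groups on the same ring carbon, such as a hydroxyl, a methoxy or a primary amine. They also leave open how the full size of the step compares with the difference between compound 2 and a compound carrying an unsubstituted piperidine, and whether the same exchange would have a similar effect in another core.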